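The source may report more compounds than this note shows. Statements on the series, on what has been measured and on what is new or still open speak of the compounds shown alone.

Measured so far:
compound 1 `O=C(Nc1cccc(-c2oc3cc(-c4ccc(F)cc4)ccc3c(=O)c2O)c1)c1ccc(F)cc1F`, 10700 nM
compound 2 `O=C(Nc1cccc(-c2oc3cc(-c4ccc(F)cc4)ccc3c(=O)c2O)c1)c1ccc(Cl)nc1`, 4080 nM

In a functional assay on HeLa cells (Homo sapiens) for antiproliferative activity, read by CCK-8 assay, with a stated time of 72 h (a higher number here means a weaker inhibitor, a lower number a stronger inhibitor), compound 1 gives 10700 nM and compound 2 gives 4080 nM. For the measured compounds named here, compound 1 stands at the highest of the two numbers; the single measured step, a 2.6-fold lower number from compound 1 to compound 2 (0.42 log units; beyond the scatter), is modest but beyond the scatter.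

Compound 3 `O=C(Nc1cccc(-c2oc3cc(-c4ccc(F)cc4)ccc3c(=O)c2O)c1)c1ccc([N+](=O)[O-])cc1` is not yet measured. Relative to compound 1 the change is 4-nitrophenyl in place of 2,4-difluorophenyl on a carbonyl carbon. Going by the values given here, the only measured step bearing on this is a 2.6-fold lower number from compound 1 to compound 2 (0.42 log units; beyond the scatter), where another six-membered aromatic ring replaced the same 2,4-difluorophenyl on the carbonyl carbon. Among the compounds with values here, no measured compound carries a 4-nitrophenyl, so the guidance is indirect. Within the data shown here, the one exchange at this position moved the number down modestly; for compound 3 a step of comparable size in the same direction, or none beyond the scatter, is expected. For compound 3 the expected value is 7000 nM, within 2500 nM to 20000 nM. This corresponds to an expected step of a 1.5-fold lower number from compound 1 to compound 3 (0.18 log units; within the scatter).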

Compound 3, half-maximal inhibitory concentration: 12300 nM
For compound 3 the middle estimate is 1.8-fold (0.24 log units) below the measured one, within the range that was stated.
By their numbers in this assay, from the lowest: compound 2; then compounds 1 and 3 (each within the scatter of the next).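

In this assay, 4-nitrophenyl in place of the 2,4-difluorophenyl on the carbonyl carbon gives a 1.1-fold higher number from compound 1 to compound 3 (0.06 log units; within the scatter), so the earlier drop with compound 2 does not extend to every six-membered aromatic ring at this position. The 6-chloropyridin-3-yl now stands apart from both rings of carbon only: the exchange for 4-nitrophenyl gives a 3.0-fold higher number from compound 2 to compound 3 (0.48 log units; beyond the scatter), which leaves compound 2 lowest of the three, while compounds 1 and 3 lie within the scatter of each other. No measurement at hand accounts for this separation.

Compound 2 differs from the other two in both its ring nitrogen and its chlorine, so the shown compounds cannot say which of these goes with its lower number; a plain pyridin-3-yl and a 4-chlorophenyl on the same carbonyl carbon would separate the two. Also open, as far as these compounds go, is how the number responds at this position to an amine or a carboxylic acid on the ring, or to a saturated ring such as piperidine in place of the aromatic one.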